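This account rests on a few compounds, and the source may have more. Where it says the series, first, only, none or still open, it means among the compounds named here.

Measured compounds:
- compound 1, `CCn1ccc2cccc(C(c3ccc(F)cc3)n3ccnc3)c21`, gives 62 nM in an assay for inhibition of Aromatase (Homo sapiens), using microsomes; a lower number here means a stronger inhibitor, a higher number a weaker inhibitor
- compound 2, `CCn1ccc2cccc(C(c3cccc(Cl)c3)n3ccnc3)c21`, gives 170 nM in this assay
- compound 3, `CCn1ccc2cccc(C(c3ccc(Cl)cc3)n3ccnc3)c21`, gives 55 nM in this assay

Among these three, compound 3 gives the lowest number. Its nearest neighbour is compound 1, and the step of a 1.1-fold lower number from compound 1 to compound 3 (0.05 log units; within the scatter) lies within the scatter, so the two cannot be ranked against each other. The step of a 3.1-fold lower number from compound 2 to compound 3 (0.49 log units; beyond the scatter) is beyond the scatter, and so is a 2.7-fold higher number from compound 1 to compound 2 (0.44 log units; beyond the scatter), both tied to moving the chloro from one position of the phenyl ring to the other.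

Compound 4, `CCn1ccc2cccc(C(c3ccc(Br)cc3)n3ccnc3)c21`, differs from compound 3 by bromo in place of chloro on an aromatic carbon. Among the measured compounds shown here, the only measured step that bears directly on this change is the exchange of one such group for another at the same position, a 1.1-fold lower number from compound 1 to compound 3 (0.05 log units; within the scatter), which stayed within the scatter. The two steps beyond the scatter concern a change of position, not of the group itself, and so do not apply here. On this basis the expected step of a 1.1-fold lower number from compound 3 to compound 4 (0.04 log units; within the scatter) is none beyond the scatter. Compound 4 is therefore estimated at 50 nM, with a range from 25 nM to 110 nM.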

Compound 4, half-maximal inhibitory concentration: 70 nM
Estimate against measurement, compound 4: 1.4-fold (0.15 log units) below; low and high end bracket the measured number.
By their numbers in this assay, from the lowest: compounds 3, 1 and 4 (each within the scatter of the next); then compound 2.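

In this assay, the exchange at this place, para to a large group, now covers three halogens, and neither a 1.3-fold higher number from compound 3 to compound 4 (0.10 log units; within the scatter) nor a 1.1-fold higher number from compound 1 to compound 4 (0.05 log units; within the scatter) lies beyond the scatter, so compounds 1, 3 and 4 cannot be ranked against one another. With a 2.4-fold lower number from compound 2 to compound 4 (0.39 log units; beyond the scatter) beyond the scatter, compound 4 stands apart from compound 2 in the same direction as compounds 1 and 3, and none of the four compounds goes against this. Nothing measured here accounts for this result.

The compounds shown leave open whether a group other than a halogen at this place, such as methoxy, nitrile or an amine, would also leave the number unchanged. They also leave open whether bromo at the position held by the chloro of compound 2 would give a step like the one seen for chloro.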